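The compounds below may be only part of what the source reports. "The series", "measured", "known", "first", "only" and "open" are said of these compounds alone.

Compound 1 `N#CC1=C(N)Oc2c(N)cc3nc4ccccc4nc3c2C12C(=O)N(Cc1cnnn1-c1cccc(Br)c1)c1ccccc12` — in an ADME assay on HUVEC cells (Homo sapiens) for antiproliferative activity, read by MTT assay, with a stated time of 48 h (on this read-out higher numbers stand for weaker inhibition and lower numbers for stronger inhibition), compound 1 gives > 50000 nM, which is a limit of the assay and not a number.
Compound 2 `COc1ccc(-n2nncc2CN2C(=O)C3(C(C#N)=C(N)Oc4c(N)cc5nc6ccccc6nc5c43)c3ccccc32)cc1` — in this assay compound 2 gives > 50000 nM, again a limit of the assay.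
Compound 3 `Cc1cc(C)cc(-n2nncc2CN2C(=O)C3(C(C#N)=C(N)Oc4c(N)cc5nc6ccccc6nc5c43)c3ccccc32)c1` — in this assay compound 3 gives > 50000 nM, again a limit of the assay.

Compound 3 therefore stands nowhere that can be ranked: all three measured compounds sit at the same point, (the limit of > 50000 nM in this assay, at which 3 of the 3 values shown sit). The three aryl swaps on the triazole nitrogen give a step that the two limits leave unreadable from compound 1 to compound 2, a step that the two limits leave unreadable from compound 1 to compound 3 and a step that the two limits leave unreadable from compound 2 to compound 3, none of them readable in size or direction.

Compound 4 `Cc1ccc(Cl)cc1-n1nncc1CN1C(=O)C2(C(C#N)=C(N)Oc3c(N)cc4nc5ccccc5nc4c32)c2ccccc21` carries 5-chloro-2-methylphenyl in place of 3,5-dimethylphenyl on an aromatic nitrogen. Every measured step on this position is unreadable, so nothing in the series points to a shift away from the limit; the expectation is that the step from compound 3 to compound 4 is likewise not readable, a step that the limit leaves unreadable from compound 3 to compound 4. Compound 4 is accordingly expected to report only a limit in this assay, with a nominal estimate of 100000 nM and a range from 40000 nM to 300000 nM.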

Compound 4, half-maximal inhibitory concentration: > 50000 nM
Compound 4 gave a limit, no number; the forecaster's own chance of this, stated with the estimate: 85%; the middle value does not contradict the limit.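

The steps from compound 1, compound 2 and compound 3 to compound 4 cannot be read, as compound 4 gives only a limit in this assay, like the others: the limit of > 50000 nM in this assay, at which 4 of the 4 values shown sit.

The compounds shown leave open how the four groups on the aromatic nitrogen rank against one another in this assay.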